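Benzamidomethyl for 4-bromophenyl on the shared core

The compounds below may be only part of what the source reports. "The series", "measured", "known", "first", "only" and "open" are said of these compounds alone.

Measured so far in a functional assay on A549 cells (Homo sapiens) for inhibition, read by MTT assay, with a stated time of 72 h; on this read-out lower numbers stand for stronger inhibition and higher numbers for weaker inhibition:
- compound 1 `Clc1ccc(-c2nnc(SCCCN3CCN(c4nc5ccccc5s4)CC3)o2)cc1` gives 110000 nM 
- compound 2 `Brc1ccc(-c2nnc(SCCCN3CCN(c4nc5ccccc5s4)CC3)o2)cc1` gives 62500 nM 

Going by the values given here, compound 2 cannot be separated from compound 1, the only other number (a 1.8-fold lower number from compound 1 to compound 2 (0.25 log units; within the scatter)). Compound 3 `O=C(NCc1nnc(SCCCN2CCN(c3nc4ccccc4s3)CC2)o1)c1ccccc1` carries the next change, benzamidomethyl in place of 4-bromophenyl on an aromatic carbon. Among the compounds with values here, the sole measured step, bromo in place of chloro, stayed small but concerns a different exchange, and no measured compound carries benzamidomethyl. No step beyond the scatter is therefore expected in this assay, with wide uncertainty. The expected change is a 1.1-fold higher number from compound 2 to compound 3 (0.05 log units; within the scatter) as estimated here. For compound 3 the estimated value is 70000 nM ( expected range 20000 nM to 200000 nM).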

Compound 3, half-maximal inhibitory concentration: 88700 nM
Estimate against measurement, compound 3: 1.3-fold (0.10 log units) below, within the range that was stated.
By their numbers in this assay, from the lowest: compounds 2, 3 and 1 (each within the scatter of the next).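

In this assay this aromatic carbon accommodates more than a halogen exchange: benzamidomethyl, with its hydrogen-bond donor and acceptor, stays within the scatter of both halophenyl groups (a 1.4-fold higher number from compound 2 to compound 3 (0.15 log units; within the scatter); a 1.2-fold lower number from compound 1 to compound 3 (0.09 log units; within the scatter)). A halophenyl group directly on this carbon is therefore not required to keep the number in this range. No available measurement explains this result.

From the compounds shown here alone, all three numbers lie within the scatter, so it remains open whether any change at this carbon can produce a step beyond it. An aminomethyl group, a carboxylic acid or a longer chain here remains untested in the compounds shown.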